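Swapping fluoro for trifluoromethyl on an inactive scaffold

The source may report more compounds than this note shows. Statements on the series, on what has been measured and on what is new or still open speak of the compounds shown alone.

Of the compounds shown here, two built on the same core have been tested in a functional assay on A549 cells (Homo sapiens) for antiproliferative activity, read by MTT assay, with a stated time of 48 h; a higher number here means a weaker inhibitor, a lower number a stronger inhibitor. Compound 1 is `O=C(/C=C\Nc1ccc(C(F)(F)F)cc1)c1cn(-c2ccccc2)nc1-c1ccccc1`. In this assay compound 1 gives > 50000 nM, which is a limit of the assay rather than a measured number. Compound 2 is `O=C(/C=C\Nc1ccc(F)cc1)c1cn(-c2ccccc2)nc1-c1ccc(Cl)cc1`. Compound 2 in this assay gives > 50000 nM, again a limit and not a number. For the measured compounds named here, both results therefore sit at the limit of > 50000 nM in this assay, at which 2 of the 2 values shown sit, so neither compound has a measured potency to compare, and no measured step between them can be stated.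

Compound 3 is `O=C(/C=C\Nc1ccc(C(F)(F)F)cc1)c1cn(-c2ccccc2)nc1-c1ccc(Cl)cc1`. It differs from compound 2 by trifluoromethyl in place of fluoro on an aromatic carbon. The change is small and concerns only the substituent on the anilino ring; compound 1 already carries the trifluoromethyl group at that same place and is also at the limit. Going by the values given here, since no measured step is available, the step expected from compound 2 to compound 3 is a step that the limit leaves unreadable from compound 2 to compound 3, meaning no change beyond the scatter and most likely another limit. For compound 3 the expected value in this assay is 80000 nM, within a range from 30000 nM to 300000 nM.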

Compound 3, half-maximal inhibitory concentration: > 50000 nM
Compound 3 was reported as a limit; the forecaster's own chance of this, stated with the estimate: 85%; the middle value lies beyond the limit too.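

In this assay, the steps from compound 2 to compound 3 and from compound 1 to compound 3 cannot be read, since compound 1, compound 2 and compound 3 all stay at the same assay limit: the limit of > 50000 nM in this assay, at which 3 of the 3 values shown sit.

The compounds shown leave open whether trifluoromethyl, fluoro or chloro makes any difference on this shared core, since none gives a measured potency.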